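Swapping pyrrolidin-1-yl for diethylamino

The source may hold more compounds than are shown below. What is called first, only, known or untested is meant among the compounds shown, and "the series" means these compounds.

In a functional assay on HCT-116 cells (Homo sapiens) for antiproliferative activity, with a stated time of 48 h (a lower number here means a stronger inhibitor, a higher number a weaker inhibitor), compound 1 (`CC(=O)c1ccc(-c2ccc(N3CCCC3)nn2)cc1`) gives > 25000 nM as a limit and not a number. Compound 2 (`COc1ccc(Nc2ccc(-c3ccccc3)nn2)cc1`) gives > 25000 nM as a limit too. Going from compound 1 to compound 3 (`CCN(CC)c1ccc(-c2ccc(C(C)=O)cc2)nn1`) puts diethylamino in place of pyrrolidin-1-yl on an aromatic carbon. Among the compounds with values here, compound 1 sits at the limit of > 25000 nM in this assay, at which 2 of the 2 values shown sit, and no measured step shows what this exchange does, so no change beyond the usual scatter is expected in this assay here. The estimated step that the limit leaves unreadable from compound 1 to compound 3 is correspondingly small. Compound 3 is expected at 28000 nM with an estimated range from 12000 nM to 60000 nM overall.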

Compound 3, half-maximal inhibitory concentration: 6000 nM
For compound 3 the middle estimate is 4.7-fold (0.67 log units) above the measured one; measured number outside the range, below it.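

The earlier compounds shown here left this position unread, and here one exchange on it counts. In this assay diethylamino in place of pyrrolidin-1-yl gives an at least 4.1-fold lower number from compound 1 to compound 3 (0.61 log units; beyond the scatter) even though both groups hold the same count of heavy atoms, so in this one pair the group without a ring goes with the stronger inhibition. Compound 3 also gives a true number and not a limit.

As far as these compounds go, the full size of the step stays open because compound 1 carries only a limit: the limit of > 25000 nM in this assay, at which 2 of the 3 values shown sit. From the compounds shown here alone, whether dimethylamino, morpholine or a longer chain such as dipropylamino would do better at this place also stays open.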